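A few compounds are considered here, and "the series" means these few. Any claim that something is new, unique, unknown or untested is made for them only; others in the source may bear on it.

Measured compounds and their values in a functional assay on Caco-2 cells (Homo sapiens) for inhibition, read by MTT assay, with a stated time of 48 h, tested at 10 uM; a higher number here means more inhibition of growth at the concentration tested, a lower number less inhibition of growth:
compound 1 `Cc1oc2c([C@H]3CCN(C)C[C@H]3O)c(O)cc(O)c2c(=O)c1C(O)c1ccc([N+](=O)[O-])cc1`: 5%
compound 2 `Cc1oc2c([C@H]3CCN(C)C[C@H]3O)c(O)cc(O)c2c(=O)c1C(O)c1ccccc1Br`: 7%
compound 3 `Cc1oc2c([C@H]3CCN(C)C[C@H]3O)c(O)cc(O)c2c(=O)c1C(O)c1c(Cl)cccc1Cl`: 24%

Of these three, compound 3 stands highest, at 24%. Compound 4 `Cc1oc2c([C@H]3CCN(C)C[C@H]3O)c(O)cc(O)c2c(=O)c1C(O)c1cc(F)cc(F)c1` has not yet been measured. It differs from compound 3 by one swap, 3,5-difluorophenyl in place of 2,6-dichlorophenyl on a saturated chain carbon bound to an aromatic carbon and an oxygen on a saturated carbon: 3,5-difluorophenyl in place of 2,6-dichlorophenyl, on a saturated chain carbon bound to an aromatic carbon and an oxygen on a saturated carbon.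

All three measured steps involve this same place. Two are modest and beyond the scatter, a number 19 percentage points higher from compound 1 to compound 3 (beyond the scatter) and a number 17 percentage points higher from compound 2 to compound 3 (beyond the scatter), and both lead to compound 3. The third, a number 2 percentage points higher from compound 1 to compound 2 (within the scatter), stays within the scatter. So far, only the 2,6-dichlorophenyl group of compound 3 stands apart, and compound 4 gives it up. For the measured compounds named here, no measured compound carries fluorine, so this expectation is loose. A modest fall is expected, with the estimated step being a number 14 percentage points lower from compound 3 to compound 4 (beyond the scatter). For compound 4, the estimated value is 10%, with an expected range of 2% to 25%.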

Compound 4, percent growth inhibition at one concentration: 10%
Beside the measured number, compound 4's estimate shows no gap at the digits printed; measured number inside the range.
By their numbers in this assay, from the lowest: compounds 1, 2 and 4 (each within the scatter of the next); then compound 3.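

In this assay, moving from the 2,6-dichlorophenyl group to the 3,5-difluorophenyl group gives a number 14 percentage points lower from compound 3 to compound 4 (beyond the scatter), so the standing of compound 3 does not carry over to this other dihalogenated ring. The new group also gives a number 3 percentage points higher from compound 2 to compound 4 (within the scatter) and a number 5 percentage points higher from compound 1 to compound 4 (within the scatter), which places compound 4 with the two weaker compounds and leaves compound 3 alone among the four. Carrying two halogen atoms on the phenyl ring is therefore not enough by itself to match compound 3, and nothing measured here explains the difference.

The compounds shown leave open whether the chlorine atoms themselves or their placement on the ring sets compound 3 apart. They also leave open what an unsubstituted phenyl, an amine or a carboxylic acid would do at this place.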